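The compounds below may be only part of what the source reports. "The series", "measured", "known", "first", "only" and "open" are said of these compounds alone.

Of the compounds shown here, two built on one shared core have so far been tested in a functional assay on JAR cells (Homo sapiens) for inhibition, read by MTT assay, with a stated time of 72 h, tested at 10 uM; on this read-out lower numbers stand for less inhibition and higher numbers for more inhibition at the one concentration tested (going by the name of the read-out). Compound 1, `CCOC(=O)C1=C(Nc2cccc(F)c2)S/C(=C\c2ccc[nH]2)C1=O`, gives 45.4%. Compound 2, `CCOC(=O)C1=C(Nc2ccc(C(F)(F)F)cc2)S/C(=C\c2ccc[nH]2)C1=O`, gives 38.5%. The gap between these two numbers falls within the usual scatter of repeated measurements of this kind, so compound 2 stands level with compound 1 on this read-out, and neither number can be called the higher or the lower of the pair.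

Compound 3, `CCOC(=O)C1=C(Nc2ccc(CC)cc2)S/C(=C\c2ccc[nH]2)C1=O`, has not yet been measured. It differs from compound 2 in one place: ethyl in place of trifluoromethyl on an aromatic carbon. Going by the values given here, no pair of measured compounds shows what such a swap does, and the two numbers that exist sit close together. Nothing in the measured pair points in either direction, so the expectation for the step from compound 2 to compound 3 is one of no change beyond the scatter, a number 1.5 percentage points higher from compound 2 to compound 3 (within the scatter). Compound 3 is therefore expected to give about 40% in this assay, with a range from 22% to 58% kept wide, as the data are few.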

Compound 3, a percentage reported as inhibition, at one concentration (the size of the read-out at that concentration, not a potency): < 10%
Compound 3: a limit, no number; the forecaster's own chance of this, stated with the estimate: 2%; middle value at least 30 percentage points away from the limit.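

In this assay compound 3 gives < 10%, which is a limit of the assay and not a number: the limit of < 10% in this assay, at which 1 of the 3 values shown sits.

Ethyl in place of trifluoromethyl on this aromatic carbon gives a number at least 28.5 percentage points lower from compound 2 to compound 3 (beyond the scatter), a step that clears the scatter, as the earlier pair did not. This position is therefore not indifferent to what sits on it, even though neither group carries a ring, a hydrogen-bond donor, a hydrogen-bond acceptor or a charge. With 4-ethylphenyl in place of 3-fluorophenyl on the amine nitrogen, the change gives a number at least 35.4 percentage points lower from compound 1 to compound 3 (beyond the scatter), so the ethyl compound stands clear of both earlier compounds.

The compounds shown do not say why the reading changes, nor whether ethyl takes the inhibition away or trifluoromethyl supports it. A methyl, a longer chain such as propyl, an amine or a carboxylic acid on this same aromatic carbon would show whether the loss is particular to ethyl or extends to other groups that replace trifluoromethyl.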